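Ethynyl on the Fused Ring of a Urea Series

The source may report more compounds than this note shows. Statements on the series, on what has been measured and on what is new or still open speak of the compounds shown alone.

Three compounds in this set share a urea linking a tert-butyl-isoxazole to a phenyl ring that carries a fused bicyclic group, and each has been tested in a functional assay on MV4-11 cells (Homo sapiens) for cytotoxicity, read by MTT assay, with a stated time of 72 h; a higher number here means a weaker inhibitor, a lower number a stronger inhibitor. Compound 1, with structure `CC(C)(C)c1cc(NC(=O)Nc2ccc(-c3cn4ccccc4n3)cc2)no1`, gives 3.09 nM and stands at the lowest number among the three. Compound 2, with structure `CC(C)(C)c1cc(NC(=O)Nc2ccc(-c3nc4ccccc4s3)cc2)no1`, gives 172 nM; swapping the fused ring system produces a large step, a 56-fold higher number from compound 1 to compound 2 (1.75 log units; beyond the scatter). Compound 3, with structure `CC(C)(C)c1cc(NC(=O)Nc2ccc(-c3cn4ccc(Br)cc4n3)cc2)no1`, gives 9.59 nM; adding bromo on the fused ring gives a modest step, a 3.1-fold higher number from compound 1 to compound 3 (0.49 log units; beyond the scatter).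

Compound 4, with structure `C#Cc1ccc2nc(-c3ccc(NC(=O)Nc4cc(C(C)(C)C)on4)cc3)cn2c1`, is not yet measured. It differs from compound 1 by ethynyl in place of hydrogen on an aromatic carbon. Only the bromo addition in compound 3 bears directly on this kind of change, since it also places a small group on the same fused ring system, and it raised the number modestly. The ring swap in compound 2 is a different sort of change and offers no guide here. A modest rise in the number, beyond the scatter but well short of the ring swap, is therefore the expectation. In this assay compound 4 is expected to give about 7 nM, between 2.5 nM and 20 nM, which means an expected step of a 2.3-fold higher number from compound 1 to compound 4 (0.36 log units; beyond the scatter).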

Compound 4, half-maximal inhibitory concentration: 8.62 nM
Compound 4: middle estimate off by 1.2-fold (0.09 log units), on the low side, within the range that was stated.
By their numbers in this assay, from the lowest: compound 1; then compounds 4 and 3 (each within the scatter of the next); then compound 2.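

In this assay, ethynyl on this aromatic carbon, two atoms from the ring nitrogen, gives a 2.8-fold higher number from compound 1 to compound 4 (0.45 log units; beyond the scatter), so ethynyl is accepted here at a modest cost. That cost is small beside a 56-fold higher number from compound 1 to compound 2 (1.75 log units; beyond the scatter), the step that came with exchanging the whole fused ring system, and it is of the same modest class as a 3.1-fold higher number from compound 1 to compound 3 (0.49 log units; beyond the scatter), the step for bromo, so compound 4 adds a second small group on the fused ring that leaves the number in the low nanomolar region. No measurement here bears on why ethynyl raises the number at all, so the step stands as an observation without an explanation.

As far as these compounds go, what an amine, a methoxy group or a longer chain such as propynyl would do on this same carbon stays open, so the limit on what this position accepts cannot be drawn from two small groups. It is equally open whether ethynyl would give a step of this size on another carbon of the fused ring, since the compounds shown place it on only one.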